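The source may hold more compounds than are shown below. What is called first, only, known or untested is meant among the compounds shown, and "the series" means these compounds.

In a functional assay on DU-145 cells (Homo sapiens) for inhibition, read by MTT assay, with a stated time of 48 h (a lower number here means a stronger inhibitor, a higher number a weaker inhibitor), two compounds sharing one core have been measured so far. Compound 1 `CS(=O)(=O)Nc1ccc(-n2cc(COc3ccccc3Cl)nn2)cc1Oc1ccccc1` gives 21100 nM, while compound 2 `Cc1cc(OCc2cn(-c3ccc(NS(C)(=O)=O)c(Oc4ccccc4)c3)nn2)ccc1Cl` gives 5900 nM, the lower of the two numbers. Compound 3 `CS(=O)(=O)Nc1ccc(-n2cc(COc3ccc4ccccc4c3)nn2)cc1Oc1ccccc1` has not yet been measured. It differs from compound 2 at a single place, on an oxygen on a saturated carbon, where naphthalen-2-yl stands in place of 4-chloro-3-methylphenyl: naphthalen-2-yl in place of 4-chloro-3-methylphenyl on an oxygen on a saturated carbon. Among the measured compounds shown here, only one measured step bears on this change. It was made at the same place, where 4-chloro-3-methylphenyl replaced 2-chlorophenyl, and a 3.6-fold lower number from compound 1 to compound 2 (0.55 log units; beyond the scatter) shows that a change there can move the number by a modest amount. For the measured compounds named here, no measured compound carries naphthalen-2-yl, so the data fix no clear direction for the new step, and a change of about that modest size in either direction remains possible. The expectation is therefore a small rise in the number, perhaps none beyond the scatter, and the estimate is a 1.3-fold higher number from compound 2 to compound 3 (0.10 log units; within the scatter). For compound 3 the estimated value is 7500 nM, with an expected range from 2500 nM to 22000 nM.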

Compound 3, half-maximal inhibitory concentration: 9100 nM
Beside the measured number, compound 3's estimate is 1.2-fold (0.08 log units) below it; the range from low to high includes it.
By their numbers in this assay, from the lowest: compounds 2 and 3 (each within the scatter of the next); then compound 1.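

In this assay, the place on an oxygen on a saturated carbon takes naphthalen-2-yl, with its 10 heavy atoms and 2 six-membered aromatic rings of carbon only, in place of 4-chloro-3-methylphenyl, and a 1.5-fold higher number from compound 2 to compound 3 (0.19 log units; within the scatter) shows no change that can be told from the scatter. Chlorine is therefore not needed at this place for a number in this range, since naphthalen-2-yl carries none, and its presence alone does not set the level: 2-chlorophenyl also carries chlorine, yet replacing it with naphthalen-2-yl gives a 2.3-fold lower number from compound 1 to compound 3 (0.37 log units; beyond the scatter). No measurement shown here accounts for these steps, so the reason for them remains unknown.

Going by these compounds, all three compounds carry an aromatic ring of carbon only at this place, so it remains open whether a cyclohexyl ring, a longer alkyl chain or a group bearing an amine or a carboxylic acid would keep the number in this range. On these data alone, it is also open whether these steps would hold on a core other than the shared one, as every number here comes from this assay.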